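Dichlorophenyl replaces isopropyl on the piperazine nitrogen

A few compounds are considered here, and "the series" means these few. Any claim that something is new, unique, unknown or untested is made for them only; others in the source may bear on it.

Of the compounds shown here, three on the shared core have been tested in a functional assay on DU-145 cells (Homo sapiens) for cytotoxicity, read by sulforhodamine B assay, with a stated time of 48 h; a higher number here means that more compound is tolerated, a lower number that less compound is tolerated. Compound 1 `CC(=O)N1CCN(c2nc(Nc3ccc(C#N)c(C(F)(F)F)c3)nc(Oc3ccnc4ccccc34)n2)CC1` reaches only the limit of the assay, giving > 100000 nM. Compound 2 `N#Cc1ccc(Nc2nc(Oc3ccnc4ccccc34)nc(N3CCN(c4ccccn4)CC3)n2)cc1C(F)(F)F` likewise stops at a limit, with > 100000 nM. Compound 3 `CC(C)N1CCN(c2nc(Nc3ccc(C#N)c(C(F)(F)F)c3)nc(Oc3ccnc4ccccc34)n2)CC1` also gives no number but a limit, > 100000 nM. Because all three sit at the limit of > 100000 nM in this assay, at which 3 of the 3 values shown sit, none of the steps among them can be read: a step that the two limits leave unreadable from compound 1 to compound 2, a step that the two limits leave unreadable from compound 1 to compound 3 and a step that the two limits leave unreadable from compound 2 to compound 3 all stay hidden behind the limits. Compound 3 therefore stands at the same limit as the other two, and nothing in these numbers orders it against them.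

Compound 4 `N#Cc1ccc(Nc2nc(Oc3ccnc4ccccc34)nc(N3CCN(c4cccc(Cl)c4Cl)CC3)n2)cc1C(F)(F)F` is the next step from compound 3: 2,3-dichlorophenyl in place of isopropyl on an amine nitrogen in a ring. Among the compounds with values here, the measured steps that bear on it are the three changes on the same ring nitrogen, and each of them was unreadable; no step so far has moved any compound off the limit. No size or direction can be drawn from them. The expectation for compound 4 is therefore that it stays at the limit as well, and the step of a number no higher from compound 3 to compound 4 (the limit leaves the size open) is estimated as essentially none. Compound 4 is expected to give 100000 nM, with a range from 30000 nM to 300000 nM in this assay.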

Compound 4, concentration lethal to 50% of the cells: > 100000 nM
Compound 4: no number, only a limit (the forecaster's own chance of this, stated with the estimate: 80%); the middle value sits exactly at the limit.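

In this assay compound 4 gives > 100000 nM, which is a limit and not a number. The steps linking compound 1, compound 2 and compound 3 to compound 4 therefore cannot be read: the limit of > 100000 nM in this assay, at which 4 of the 4 values shown sit.

The compounds shown leave open whether any group on this ring nitrogen would give a measurable value in this assay.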